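This account rests on a few compounds, and the source may have more. Where it says the series, first, only, none or still open, it means among the compounds named here.

Going by the values given here, in a functional assay on MCF7 cells (Homo sapiens) for cytotoxicity, read by MTT assay, with a stated time of 72 h (a lower number here means a stronger inhibitor, a higher number a weaker inhibitor), compound 2 `FC(F)(F)c1ccc(CSc2nc(Nc3cccc(C(F)(F)F)c3)c3ccccc3n2)cc1` gives 15300 nM, the only actual number among the two values shown. Compound 1 `FC(F)(F)c1ccc(CSc2nc(Nc3ccccc3C(F)(F)F)c3ccccc3n2)cc1` reaches only the assay limit of > 50000 nM there. Among the compounds with values here, the one measured step, an at least 3.2-fold lower number from compound 1 to compound 2 (0.51 log units; beyond the scatter), moves the trifluoromethyl group on the aryl nitrogen substituent and is at least modest. Compound 3 `FC(F)(F)c1ccc(CSc2nc(Nc3cccc(Br)c3)c3ccccc3n2)cc1` differs from compound 2 by bromo in place of trifluoromethyl on an aromatic carbon. Within the data shown here, no measured step covers this exchange, so compound 3 is expected to show no change beyond the scatter, the step of a 1.0-fold lower number from compound 2 to compound 3 (0.01 log units; within the scatter) being the estimate. Compound 3 is estimated at 15000 nM, with a range from 5000 nM to 50000 nM.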

Compound 3, half-maximal inhibitory concentration: 25600 nM
For compound 3 the middle estimate is 1.7-fold (0.23 log units) below the measured one, and the stated range covers the measured number.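

In this assay, bromo in place of trifluoromethyl on this aromatic carbon is a step of a 1.7-fold higher number from compound 2 to compound 3 (0.22 log units; within the scatter), so this assay does not tell the two groups apart here. The comparison with the other aryl placement is less firm, with an at least 1.9-fold lower number from compound 1 to compound 3 (0.29 log units; that floor lies within the scatter), a floor and not a measured gap. Compound 1 stands at a limit and not at a number: the limit of > 50000 nM in this assay, at which 1 of the 3 values shown sits.

Going by these compounds, whether an amine or a carboxylic acid on this aromatic carbon would move the number beyond the scatter stays open. So does what bromo would give in the place held by the trifluoromethyl of compound 1.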